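The source may hold more compounds than are shown below. What is called first, only, known or untested is meant among the compounds shown, and "the series" means these compounds.

Two compounds of this series have been run in an assay on isolated protein for inhibition of serine/threonine-protein kinase PLK1 (Homo sapiens), read by radiometric assay and 33P incorporation, with a stated time of 40 min, tested at 20 uM, in the presence of a further agent that is not named here; a higher number here means more inhibition at the concentration tested (going by the name of the read-out), a lower number less inhibition. Compound 1, `CCNc1cc(-c2ccc(NC(=O)Nc3cccc4ccccc34)cc2C)ccn1`, gives 35.3%. Compound 2, `CCNc1cc(-c2ccc(NC(=O)Nc3ccc(C)cc3)cc2C(F)(F)F)ccn1`, gives 42.6%; the gap between the two falls within the scatter of repeated measurements of this kind, so neither compound can be placed above the other on the numbers shown. The next compound, compound 3, `CCNc1cc(-c2ccc(NC(=O)Nc3ccccc3Cl)cc2C(F)(F)F)ccn1`, keeps the core of compound 2 and differs from it in one place: 2-chlorophenyl in place of 4-methylphenyl on an amide-type nitrogen. For the measured compounds named here, no measured pair isolates this change, so nothing here shows how this assay responds to it. Going by the values given here, with no step of this kind known, the expected change is one that stays within the scatter, estimated as a number 2.6 percentage points lower from compound 2 to compound 3 (within the scatter). Compound 3 is therefore estimated at 40% in this assay, with a range from 20% to 60%.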

Compound 3, a percentage reported as inhibition, at one concentration (the size of the read-out at that concentration, not a potency): 71.6%
Beside the measured number, compound 3's estimate is 31.6 percentage points below it; measured number above the stated range.
By their numbers in this assay, from the lowest: compounds 1 and 2 (each within the scatter of the next); then compound 3.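

In this assay, the amide-type nitrogen whose other neighbour is the carbonyl carbon proves a responsive place: 2-chlorophenyl in place of 4-methylphenyl gives a number 29 percentage points higher from compound 2 to compound 3 (beyond the scatter) with the rest of the structure held constant. For the compounds shown here, this is the first step that isolates a single change, and it lies beyond the scatter, so the group at this place can move the read-out. Nothing available here bears on the origin of this step.

The step exchanges methyl for chlorine and also changes where the substituent sits on the phenyl ring, and the compounds shown do not separate these two differences. Unsubstituted phenyl at this place would give a reference for both groups, and an amine or a carboxylic acid on that ring remains an open comparison.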